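The source may report more compounds than this note shows. Statements on the series, on what has been measured and on what is new or still open speak of the compounds shown alone.

In an ADME assay (liver) for metabolic stability, with Liver microsome (Rattus norvegicus) as the target, using microsomes and NADPH, with a stated time of 30 min, tested at 1 uM (on this read-out lower numbers stand for slow clearance and higher numbers for fast clearance), compound 3 `Cc1ccc(-c2cc(C(O)(C(F)(F)F)C(F)(F)F)cnc2N2CCN(S(=O)(=O)c3ccc(N)nc3)CC2)cn1` gives 182 mL.min-1.g-1 and stands highest of the three numbers, over compound 1 `CS(=O)(=O)Nc1cccc(-c2cc(C(O)(C(F)(F)F)C(F)(F)F)cnc2N2CCN(S(=O)(=O)c3ccc(N)nc3)CC2)c1` at 81 mL.min-1.g-1 and compound 2 `Nc1ccc(S(=O)(=O)N2CCN(c3ncc(C(O)(C(F)(F)F)C(F)(F)F)cc3-c3ccncc3)CC2)cn1` at 31 mL.min-1.g-1 in the same read-out. Compound 4 `Nc1ccc(S(=O)(=O)N2CCN(c3ncc(C(O)(C(F)(F)F)C(F)(F)F)cc3-c3ccc4scnc4c3)CC2)cn1` has 1,3-benzothiazol-5-yl in place of 6-methylpyridin-3-yl on an aromatic carbon. The steps of a 2.6-fold lower number from compound 1 to compound 2 (0.42 log units; beyond the scatter) and a 2.2-fold higher number from compound 1 to compound 3 (0.35 log units; beyond the scatter) and a 5.9-fold higher number from compound 2 to compound 3 (0.77 log units; beyond the scatter) at this same place are modest, yet beyond the scatter, and run both ways. None involves 1,3-benzothiazol-5-yl, so a step no larger than these is expected in this assay and, with compound 3 on top at 182 mL.min-1.g-1 here, the expectation leans lower. The expected step is small (a 1.5-fold lower number from compound 3 to compound 4 (0.18 log units; within the scatter)). Compound 4 is estimated at 120 mL.min-1.g-1 (range 50 mL.min-1.g-1 to 280 mL.min-1.g-1).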

Compound 4, intrinsic clearance in microsomes: 147 mL.min-1.g-1
For compound 4 the middle estimate is 1.2-fold (0.09 log units) below the measured one; measured number inside the range.
By their numbers in this assay, from the lowest: compound 2; then compounds 1, 4 and 3 (each within the scatter of the next, the first and the last beyond it).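

In this assay, among these compounds, 1,3-benzothiazol-5-yl, the only group here with a five-membered aromatic ring, gives a 1.2-fold lower number from compound 3 to compound 4 (0.09 log units; within the scatter) and so sits level with 6-methylpyridin-3-yl, while a 1.8-fold higher number from compound 1 to compound 4 (0.26 log units; within the scatter) also leaves it level with 3-(methanesulfonamido)phenyl. Among the four compounds, pyridin-4-yl alone separates from it, with a 4.7-fold higher number from compound 2 to compound 4 (0.68 log units; beyond the scatter) as the step. No data here bear on the cause of this separation. Still open, on these data alone, is whether an amine or a carboxylic acid on this aromatic carbon would give a number nearer compound 2 or nearer compound 4.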